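Replacing the sulfur-bearing group on a shared core

The source may report more compounds than this note shows. Statements on the series, on what has been measured and on what is new or still open speak of the compounds shown alone.

In a functional assay on A549 cells (Homo sapiens) for antiproliferative activity, read by MTT assay, with a stated time of 48 h (on this read-out lower numbers stand for stronger inhibition and higher numbers for weaker inhibition), two compounds with the same core have been measured so far. Compound 1 `CC(=O)OC/C1=C/C[C@](C)(CCC=C(C)C)/C=C/[C@@H](OC(=O)C=C(C)C)[C@](C)(O)/C=C/C1=O` gives 2950 nM, and compound 2 `CSC(=S)OC/C1=C/C[C@](C)(CCC=C(C)C)/C=C/[C@@H](OC(=O)C=C(C)C)[C@](C)(O)/C=C/C1=O` gives 380 nM, the lower of the two numbers and therefore the stronger inhibition of this pair.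

Compound 3 `CO/N=C/C1=C/C[C@](C)(CCC=C(C)C)/C=C/[C@@H](OC(=O)C=C(C)C)[C@](C)(O)/C=C/C1=O` has not yet been measured. Its structure differs from that of compound 2 by a group of 4 heavy atoms (2 carbon, 1 nitrogen, 1 oxygen; no ring) in place of a group of 6 heavy atoms (3 carbon, 1 oxygen, 2 sulfur; no ring), on a double-bonded ring carbon, a ring carbon of the shared core. The entering group holds no sulfur.

Among the measured compounds shown here, only one measured step bears on this change, and only partly: a 7.8-fold lower number from compound 1 to compound 2 (0.89 log units; beyond the scatter). That step lies beyond the scatter, and it was made inside the group that now leaves. Compound 1, whose group also holds no sulfur, sits at 2950 nM, so a move towards higher numbers in this assay is expected, though probably a smaller one than that single step. The new group has never been tested here, so this expectation is loose.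

The estimated change is a 3.4-fold higher number from compound 2 to compound 3 (0.53 log units; beyond the scatter). For compound 3 the expected value is 1300 nM, with an estimated range from 350 nM to 5000 nM.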

Compound 3, half-maximal inhibitory concentration: 3470 nM
Estimate against measurement, compound 3: 2.7-fold (0.43 log units) below; the range from low to high includes it.
By their numbers in this assay, from the lowest: compound 2; then compounds 1 and 3 (each within the scatter of the next).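

At the double-bonded ring carbon of the shared core, this assay shows (a 9.1-fold higher number from compound 2 to compound 3 (0.96 log units; beyond the scatter)) when the sulfur-bearing group gives way to the smaller group holding nitrogen and oxygen, so the low number of compound 2 does not carry over to this replacement. Compound 1 and compound 3 carry two different sulfur-free groups at this carbon, yet they read alike (a 1.2-fold higher number from compound 1 to compound 3 (0.07 log units; within the scatter)), and among these three compounds only the sulfur-bearing group of compound 2 stands apart. No accompanying measurement shows what lies behind this difference.

From the compounds shown here alone, with a single sulfur-bearing group in the set, it remains open whether the sulfur atoms themselves go with the lower number or whether it takes that whole group. A dithiocarbamate, which has nitrogen where the leaving group has oxygen, or a plain thioether on the same carbon would help separate these two readings, while an amine or a carboxylic acid there would show how far the sulfur-free groups share the reading of compound 1 and compound 3.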